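From 3-fluorophenyl to 2-fluorophenyl in a cytotoxicity read-out

A few compounds are considered here, and "the series" means these few. Any claim that something is new, unique, unknown or untested is made for them only; others in the source may bear on it.

Of the compounds shown here, three sharing one core have been measured in an ADME assay on V79 cells (Cricetulus griseus) for cytotoxicity, read by MTT assay, with a stated time of 72 h; on this read-out lower numbers stand for stronger inhibition and higher numbers for weaker inhibition. Compound 1 `COc1ccc(-n2nnnc2Nc2ccc(Br)cc2)cc1` gives 212000 nM, compound 2 `COc1ccc(-n2nnnc2Nc2ccc(F)cc2)cc1` gives 236000 nM, and compound 3 `COc1ccc(-n2nnnc2Nc2cccc(F)c2)cc1` gives 248000 nM. Compound 3 therefore stands within the scatter of both others: the data show a 1.2-fold higher number from compound 1 to compound 3 (0.07 log units; within the scatter) and a 1.1-fold higher number from compound 2 to compound 3 (0.02 log units; within the scatter).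

The open question is compound 4 `COc1ccc(-n2nnnc2Nc2ccccc2F)cc1`, which has the same atoms as compound 3, joined differently: 2-fluorophenyl in place of 3-fluorophenyl on a nitrogen on an aromatic ring. Here 2-fluorophenyl stands in place of 3-fluorophenyl on a nitrogen on an aromatic ring. Among the measured compounds shown here, the closest precedent is the exchange of 4-fluorophenyl for 3-fluorophenyl, which gave a 1.1-fold higher number from compound 2 to compound 3 (0.02 log units; within the scatter). Fluoro in place of bromo gave a 1.1-fold higher number from compound 1 to compound 2 (0.05 log units; within the scatter), so neither measured change in this group moved the number beyond the scatter. For the measured compounds named here, no compound with a 2-fluorophenyl group has yet been measured, so this precedent is indirect, and a larger step cannot be excluded. On these three compounds, no shift beyond the scatter is expected in this assay, in either direction. The expected step is a 1.0-fold lower number from compound 3 to compound 4 (0.01 log units; within the scatter). Compound 4 is estimated at 240000 nM, with an expected range from 150000 nM to 370000 nM.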

Compound 4, half-maximal inhibitory concentration: 115000 nM
The estimate for compound 4 lay 2.1-fold (0.32 log units) above the measured number; measured number below the stated range.
By their numbers in this assay, from the lowest: compounds 4, 1, 2 and 3 (each within the scatter of the next, the first and the last beyond it).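

In this assay, among the compounds shown here, the change to 2-fluorophenyl is the first in this group to pass beyond the scatter, with a 2.2-fold lower number from compound 3 to compound 4 (0.33 log units; beyond the scatter) and a 2.1-fold lower number from compound 2 to compound 4 (0.31 log units; beyond the scatter), whereas the exchange of 4-fluorophenyl for 3-fluorophenyl stayed within it. On a nitrogen on an aromatic ring, the arrangement of the same atoms in a fluorophenyl group can therefore move the number modestly, although the 4-bromophenyl comparison, a 1.8-fold lower number from compound 1 to compound 4 (0.27 log units; within the scatter), stays within the scatter and so does not set compound 4 apart from compound 1. No measurement available here accounts for the difference between 2-fluorophenyl and the other two fluorophenyl groups.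

The compounds shown leave open whether this step is particular to fluoro or would also appear with a chloro group, a methyl group or an amine in its place. From the compounds shown here alone, they also hold the rest of the shared core constant, so whether the exchange of 3-fluorophenyl for 2-fluorophenyl would keep its size on a different core remains open.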